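From a Fluorinated Ring Back to a Carboxylic Acid

The source may hold more compounds than are shown below. What is called first, only, known or untested is meant among the compounds shown, and "the series" means these compounds.

Three measured compounds share one core and differ only in the aryl group on the benzyl ether. Compound 1 `O=C1c2ccc(OCc3cccc(-c4ccc(Cl)cc4F)c3)cc2CN1C1CCCC1` carries a 4-chloro-2-fluorophenyl group; in an assay on HEK293 cells for positive allosteric modulation of metabotropic glutamate receptor 2 (Rattus norvegicus), read by thallium flux (a higher number here means that more compound is needed for the effect, a lower number that less compound is needed), compound 1 gives > 5000 nM, which is a limit of the assay and not a number. Compound 3 `O=C1c2ccc(OCc3cccc(-c4ccc(C(F)(F)F)cc4F)c3)cc2CN1C1CCCC1` carries a 2-fluoro-4-(trifluoromethyl)phenyl group, and in this assay compound 3 gives > 5000 nM, again a limit. Between them stands a step that the two limits leave unreadable from compound 1 to compound 3. Compound 2 `O=C(O)c1cc(-c2cccc(COc3ccc4c(c3)CN(C3CCCC3)C4=O)c2)ccc1O` carries a 3-carboxy-4-hydroxyphenyl group and gives 20 nM in this assay. That yields an at least 250-fold lower number from compound 1 to compound 2 (2.39 log units; beyond the scatter) and an at least 250-fold higher number from compound 2 to compound 3 (2.39 log units; beyond the scatter); compounds 1 and 3 together account for (the limit of > 5000 nM in this assay, at which 2 of the 3 values shown sit).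

Compound 4 `Cc1ccc(C(=O)O)cc1-c1cccc(COc2ccc3c(c2)CN(C2CCCC2)C3=O)c1` has not been measured. From compound 3 the change is 5-carboxy-2-methylphenyl in place of 2-fluoro-4-(trifluoromethyl)phenyl on an aromatic carbon. A carboxylic acid comes back, although the hydroxyl of compound 2 is absent and a methyl stands in the entering group instead. Both measured steps between a carboxylic-acid ring and a fluorinated ring were large, so a large drop in the number from compound 3 to compound 4 is expected, perhaps smaller than the step to compound 2 given the altered group. Compound 4 is expected to give about 100 nM, between 20 nM and 1000 nM. The expected step is an at least 50-fold lower number from compound 3 to compound 4 (1.69 log units; beyond the scatter).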

Compound 4, half-maximal effective concentration: 110 nM
Compound 4: middle estimate off by 1.1-fold (0.04 log units), on the low side; measured number inside the range.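

The hydroxyl of compound 2 turns out not to be required for a low number in this assay, as a ring carrying a carboxylic acid and a methyl instead gives an at least 45-fold lower number from compound 3 to compound 4 (1.65 log units; beyond the scatter) and an at least 45-fold lower number from compound 1 to compound 4 (1.65 log units; beyond the scatter). Both of these sizes rest on a limit of the assay and not on a number: the limit of > 5000 nM in this assay, at which 2 of the 4 values shown sit. Among the two acid-bearing compounds the ring still matters, with a 5.5-fold higher number from compound 2 to compound 4 (0.74 log units; beyond the scatter), although this change removes the hydroxyl and brings in the methyl together, so the compounds shown cannot divide the step between the two groups.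

Still open, as far as these compounds go, is whether the carboxylic acid itself is needed for the low number, or whether a tetrazole, a primary amide or a hydroxymethyl group in its place would serve as well. Also open, from the compounds shown here alone, is what each neighbouring group contributes on its own, a question that a plain 3-carboxyphenyl ring, with neither the hydroxyl nor the methyl, would help to separate.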